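The source may hold more compounds than are shown below. What is called first, only, known or untested is meant among the compounds shown, and "the series" means these compounds.

In a functional assay on KYSE-450 cells (Homo sapiens) for inhibition, read by MTT assay, with a stated time of 48 h (on this read-out lower numbers stand for stronger inhibition and higher numbers for weaker inhibition), compound 1 `CCC(=O)N(Cc1ccc(OC)c(O)c1)c1cc(OC)c(OC)c(OC)c1` gives 98 nM. Compound 2 `COc1ccc(CN(C(=O)C=C(C)C)c2cc(OC)c(OC)c(OC)c2)cc1O` gives 280 nM in this assay, and compound 3 `COc1ccc(CN(C(=O)/C=C/CBr)c2cc(OC)c(OC)c(OC)c2)cc1O` gives 100 nM. Compound 3 thus carries the second highest number of the three, close to compound 1 and apart from compound 2: the step of a 1.0-fold higher number from compound 1 to compound 3 (0.01 log units; within the scatter) lies within the scatter, while a 2.8-fold lower number from compound 2 to compound 3 (0.45 log units; beyond the scatter) is a modest step beyond it, and a 2.9-fold higher number from compound 1 to compound 2 (0.46 log units; beyond the scatter) shows the same gap seen from the other side.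

Compound 4 `CC/C=C/C(=O)N(Cc1ccc(OC)c(O)c1)c1cc(OC)c(OC)c(OC)c1` has not yet been measured. It differs from compound 3 in one place: methyl in place of bromo on a saturated chain carbon bound to a double-bonded chain carbon. Two of the measured steps bear on this change. The step of a 1.0-fold higher number from compound 1 to compound 3 (0.01 log units; within the scatter) shows that carrying the 3-bromoprop-1-en-1-yl group on the carbonyl carbon instead of ethyl left the number where it was, and a 2.8-fold lower number from compound 2 to compound 3 (0.45 log units; beyond the scatter) shows that the 2-methylprop-1-en-1-yl group gave a modestly higher number than the bromo-bearing chain. A but-1-en-1-yl chain shares features with both cases, so only a small step, a 1.4-fold higher number from compound 3 to compound 4 (0.15 log units; within the scatter), toward a somewhat higher number is expected. Compound 4 is therefore expected to give about 140 nM in this assay, within a range from 60 nM to 320 nM.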

Compound 4, half-maximal inhibitory concentration: 72 nM
For compound 4 the middle estimate is 1.9-fold (0.29 log units) above the measured one; the range from low to high includes it.
By their numbers in this assay, from the lowest: compounds 4, 1 and 3 (each within the scatter of the next); then compound 2.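

Replacing bromo with methyl on a saturated chain carbon bound to a double-bonded chain carbon leaves the read-out in this assay within the scatter, as a 1.4-fold lower number from compound 3 to compound 4 (0.14 log units; within the scatter) shows, so at this position the bromine atom is not needed to keep the number in this range. The but-1-en-1-yl and ethyl chains on the carbonyl carbon also cannot be told apart here, given a 1.4-fold lower number from compound 1 to compound 4 (0.13 log units; within the scatter). Going by these compounds alone, the only new step beyond the scatter is modest, a 3.9-fold lower number from compound 2 to compound 4 (0.59 log units; beyond the scatter), which leaves the 2-methylprop-1-en-1-yl chain of compound 2 standing apart from the three other chains, whose compounds all lie within the scatter of one another.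

From the compounds shown here alone, it remains open whether a hydroxyl group, an amine or a longer chain at this same carbon would also keep the number in this range. Nothing available explains why these chains give the numbers they do, and none of the data speak to the reason for the gap to compound 2.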